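Swapping a Tolyl Group for a Cyclohexyl Group

This account rests on a few compounds, and the source may have more. Where it says the series, first, only, none or still open, it means among the compounds named here.

Measured compounds:
- compound 1, `Cc1ccc(C(=O)Nc2nnc(-c3ccc(O)c(O)c3)s2)cc1`: 27100 nM
- compound 2, `O=C(Nc1nnc(-c2ccc(O)c(O)c2)s1)C1CCCCC1`: 24000 nM
- compound 3, `Cc1ccc(C(=O)Nc2nnc(-c3cccc(O)c3O)s2)cc1`: 33200 nM

These three compounds were tested in an ADME assay on MRC5 cells (Homo sapiens) for cytotoxicity, read by MTT assay, with a stated time of 72 h; a lower number here means a stronger inhibitor, a higher number a weaker inhibitor. Within the data shown here, compound 1 and compound 2 share one core, and the only change between them is cyclohexyl in place of 4-methylphenyl on a carbonyl carbon. That change gave a 1.1-fold lower number from compound 1 to compound 2 (0.05 log units; within the scatter), so the two numbers are effectively indistinguishable. Compound 3 is built from the same atoms as compound 1, joined differently; the difference between the two cores is not broken down here. All three values sit close to one another, and none of them can be called stronger or weaker than the others.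

Compound 4, `O=C(Nc1nnc(-c2cccc(O)c2O)s1)C1CCCCC1`, has not yet been measured. It stands to compound 3 exactly as compound 2 stands to compound 1: the change is cyclohexyl in place of 4-methylphenyl on a carbonyl carbon, and the place of the change is the same in both pairs, so this is the same change made on the other core. Since compound 1 to compound 2 showed a step within the scatter, the expectation is that compound 3 to compound 4 will behave alike, with an estimated step of a 1.1-fold lower number from compound 3 to compound 4 (0.04 log units; within the scatter) in this assay. On that basis compound 4 is expected to give about 30000 nM, most likely between 15000 nM and 60000 nM. This rests on a single earlier pair, so the estimate is held loosely.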

Compound 4, half-maximal inhibitory concentration: 70300 nM
Estimate against measurement, compound 4: 2.3-fold (0.37 log units) below; the whole stated range lies below it.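

In this assay, putting cyclohexyl in place of 4-methylphenyl on a carbonyl carbon gave a 2.1-fold higher number from compound 3 to compound 4 (0.33 log units; beyond the scatter), while on the core of compound 1 the same change gave a 1.1-fold lower number from compound 1 to compound 2 (0.05 log units; within the scatter). Only the newer step lies beyond the scatter when taken alone, yet a comparison of the two steps does not separate them: the same change on two cores in this assay, a 1.1-fold lower number (0.05 log units; within the scatter) from compound 1 to compound 2 and a 2.1-fold higher number (0.33 log units; beyond the scatter) from compound 3 to compound 4, 2.4-fold (0.38 log units) apart, within the scatter of two such steps This does not show that the change behaves differently on the two cores, and it does not prove that the change carries over unaltered either, since two pairs in a single assay are too few to settle the question and give no explanation for the numbers.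

The compounds shown leave open whether other groups on the same carbonyl carbon, such as a longer chain or an amine, would give similar numbers on both cores. They also leave open how either core would respond if a methoxy group replaced a hydroxyl group, and a third pair carrying the same cyclohexyl change on another core would be needed to show how far this change can be carried across the series.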